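A few compounds are considered here, and "the series" means these few. Any claim that something is new, unique, unknown or untested is made for them only; others in the source may bear on it.

compound 1, `O=C(Nc1ccc(-n2cc(CCO[C@H]3O[C@@H](CO)[C@H](O)[C@@H]3O)nn2)cc1)Nc1ccccc1C(F)(F)F`: "not active" (no number reported)
compound 2, `CCCCc1cn(-c2ccc(NC(=O)Nc3cc(OC4CCOC4)ccc3C)cc2)nn1`: 100 nM
compound 3, `CCCCc1cn(-c2ccc(NC(=O)Nc3cc(O[C@H]4O[C@@H](CO)[C@H](O)[C@@H]4O)ccc3C)cc2)nn1`: "not active" (no number reported)

Compound 3 stands without a number: in an assay on isolated protein for inhibition of ATP-dependent RNA helicase DDX3X (Homo sapiens), read by FRET, with stated times of 30 s and 40 min (on this read-out higher numbers stand for weaker inhibition and lower numbers for stronger inhibition), compound 3 came out as "not active" (no number reported), and compound 1 likewise came out as "not active" (no number reported). Going by the values given here, the only compound here with a number is compound 2, which shares the core of compound 3 but carries another group where compound 3 carries the 3,4-dihydroxy-5-(hydroxymethyl)oxolan-2-yl; in this assay compound 2 gives 100 nM.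

Compound 4, `CCCCc1cn(-c2ccc(NC(=O)Nc3cc(O)ccc3C)cc2)nn1`, has not been measured. It differs from compound 3 by hydrogen in place of 3,4-dihydroxy-5-(hydroxymethyl)oxolan-2-yl on an oxygen on an aromatic ring. Among the compounds with values here, no measured pair shows this step directly, so its size cannot be read from the data. Because compound 3 gave "not active" (no number reported) while compound 2 sits at 100 nM, the expectation is a step toward stronger inhibition in this assay, beyond the usual scatter, with compound 4 landing nearer to compound 2 than to compound 3. Compound 4 is estimated at 300 nM, with an expected range from 50 nM to 3000 nM.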

Compound 4, half-maximal inhibitory concentration: 490 nM
Beside the measured number, compound 4's estimate is 1.6-fold (0.21 log units) below it; the measured number falls inside the stated range.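

The change from compound 3, which gives "not active" (no number reported) in this assay, to compound 4 shows that the inactivity does not come from the shared core: with the 3,4-dihydroxy-5-(hydroxymethyl)oxolan-2-yl gone and only hydroxy left on the aromatic ring, a number returns, though the size of this step cannot be read. The group on this oxygen still counts, as removing oxolan-3-yl gives a 4.9-fold higher number from compound 2 to compound 4 (0.69 log units; beyond the scatter) and so the small ring does better than hydrogen here, while the larger oxolan-2-yl group of compound 3 leaves no measurable inhibition. Nothing measured here explains either effect.

From the compounds shown here alone, it remains open whether a methyl group or a longer carbon chain on this oxygen would match oxolan-3-yl. An amine on such a chain, or a single hydroxy on the oxolane ring, could also show which part of the larger group carries the loss.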